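Chloro to methoxy on two related cores

A few compounds are considered here, and "the series" means these few. Any claim that something is new, unique, unknown or untested is made for them only; others in the source may bear on it.

Measured compounds:
compound 1 `Cc1cc(C)c2c(O)cc(-c3ccc(Cl)cc3)nc2n1`, 14800 nM
compound 2 `COc1ccc(-c2cc(O)c3c(C)cc(C)nc3n2)cc1`, 36300 nM
compound 3 `Cc1cnc2nc(-c3ccc(Cl)cc3)cc(O)c2c1`, 2820 nM

In a functional assay on HCT-116 cells (Homo sapiens) (on this read-out higher numbers stand for weaker inhibition of growth and lower numbers for stronger inhibition of growth), compound 3 gives the lowest number of the three. The difference between the core of compound 3 and the core of compound 1 is not broken down here. Compound 1 and compound 2 share a core and differ by one change, (methoxy in place of chloro on an aromatic carbon), which gave a 2.5-fold higher number from compound 1 to compound 2 (0.39 log units; beyond the scatter).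

Compound 4 `COc1ccc(-c2cc(O)c3cc(C)cnc3n2)cc1` is not yet measured. It stands to compound 3 as compound 2 stands to compound 1: the change is methoxy in place of chloro on an aromatic carbon, the same change at the same kind of place. Among the compounds with values here, on the core of compound 3 the step is expected to be a 2.5-fold higher number from compound 3 to compound 4 (0.39 log units; beyond the scatter), resting on the one measured example, compound 1 to compound 2 with a 2.5-fold higher number from compound 1 to compound 2 (0.39 log units; beyond the scatter). The estimate for compound 4 in this assay is therefore 7000 nM, expected between 3500 nM and 14000 nM.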

Compound 4, concentration for 50% growth inhibition: 4170 nM
Compound 4: the middle estimate sits 1.7-fold (0.22 log units) above what was measured; the range from low to high includes it.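

In this assay methoxy in place of chloro on the core of compound 3 gives a 1.5-fold higher number from compound 3 to compound 4 (0.17 log units; within the scatter) and so does not stand clear of the scatter on this core. Set beside the earlier step, the change shows no measurable dependence on the core: the same change on two cores in this assay, a 2.5-fold higher number (0.39 log units; beyond the scatter) from compound 1 to compound 2 and a 1.5-fold higher number (0.17 log units; within the scatter) from compound 3 to compound 4, 1.7-fold (0.22 log units) apart, within the scatter of two such steps. This rests on two pairs and a single change, so it supports carrying the step between these two cores only and neither fixes its exact size nor explains it.

The compounds shown leave open how an amine, a carboxylic acid or a longer chain such as ethoxy would behave at this place on either core. They also leave open how the difference between the two cores breaks down into single changes.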